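The source may report more compounds than this note shows. Statements on the series, on what has been measured and on what is new or still open speak of the compounds shown alone.

Measured compounds:
- compound 1, `O=C(/C=C/c1cccc(NS(=O)(=O)c2ccc(Cl)cc2)c1)c1nc2ccccc2[nH]1`, 3820 nM
- compound 2, `Cc1ccccc1S(=O)(=O)Nc1cccc(/C=C/C(=O)c2nc3ccccc3[nH]2)c1`, 4130 nM
- compound 3, `Cc1ccc(S(=O)(=O)Nc2cccc(/C=C/C(=O)c3nc4ccccc4[nH]3)c2)cc1`, 3220 nM

These three compounds share one core and differ only in the group attached to the sulfonyl sulfur. In a functional assay on MCF7 cells (Homo sapiens) for antiproliferative activity, read by MTT assay, with a stated time of 48 h (on this read-out lower numbers stand for stronger inhibition and higher numbers for weaker inhibition), compound 3 gives the lowest of the three numbers, yet its step to compound 1 and its step to compound 2 both stay within the scatter, so no ordering among them can be claimed. The steps of a 1.1-fold higher number from compound 1 to compound 2 (0.03 log units; within the scatter), a 1.2-fold lower number from compound 1 to compound 3 (0.07 log units; within the scatter) and a 1.3-fold lower number from compound 2 to compound 3 (0.11 log units; within the scatter) all show that swapping one aryl group for another on the sulfonyl sulfur has so far left this assay essentially unchanged.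

Compound 4, `Cc1cc(C)cc(S(=O)(=O)Nc2cccc(/C=C/C(=O)c3nc4ccccc4[nH]3)c2)c1`, is not yet measured. The change from compound 3 is 3,5-dimethylphenyl in place of 4-methylphenyl on a sulfonyl sulfur. Within the data shown here, this is one more exchange of the same kind as the three measured steps, each of which fell within the scatter, and none of the measured compounds points in a direction beyond it. Compound 4 is therefore expected to show a step of a 1.0-fold higher number from compound 3 to compound 4 (0.01 log units; within the scatter), that is, no change beyond the scatter, because the prior step a 1.3-fold lower number from compound 2 to compound 3 (0.11 log units; within the scatter) was of that size. Compound 4 is estimated at 3300 nM, within the range 1600 nM to 7000 nM.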

Compound 4, half-maximal inhibitory concentration: 4570 nM
Compound 4: the middle estimate sits 1.4-fold (0.14 log units) below what was measured; the measured number falls inside the stated range.
By their numbers in this assay, from the lowest: compounds 3, 1, 2 and 4 (each within the scatter of the next).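

In this assay, among these compounds, the 3,5-dimethylphenyl group replaces the 4-methylphenyl group on the sulfonyl sulfur, taking this substituent from 7 to 8 heavy atoms and putting methyl groups at two places on the aromatic ring, and still no step leaves the scatter (a 1.4-fold higher number from compound 3 to compound 4 (0.15 log units; within the scatter)), (a 1.1-fold higher number from compound 2 to compound 4 (0.04 log units; within the scatter)) and (a 1.2-fold higher number from compound 1 to compound 4 (0.08 log units; within the scatter)). Compound 4 thus extends the flat picture from single-substituted aryl groups to a doubly substituted one, so that all four compounds remain within the scatter of the next and no ordering among them can be claimed. Nothing available here bears on why this position tolerates these exchanges.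

On these data alone, all four groups on the sulfonyl sulfur are six-membered aromatic rings of carbon only, bearing just methyl or chloro, so it remains open whether an amine or a carboxylic acid on that ring, or a longer chain such as butyl in place of the ring, would move the number beyond the scatter. The compounds also share the rest of the core, so they say nothing about how a change elsewhere in it, including on the sulfonamide nitrogen, would read in this assay.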